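Swapping the azetidine in compound 3 for a fluorooxetane ether

The source may hold more compounds than are shown below. What is called first, only, known or untested is meant among the compounds shown, and "the series" means these compounds.

Measured compounds:
compound 1 `Cc1cc(COc2cccc(S(C)(=O)=O)c2)nc(-c2ccccn2)n1` — 1.7
compound 2 `Cc1cc(COc2ccc(F)c(F)c2)nc(-c2ccccn2)n1` — 3.2
compound 3 `CC1(C)CN(c2cc(COc3ccc(F)c(F)c3F)nc(-c3ccccn3)n2)C1` — 4.3

The read-out is a physicochemical assay for lipophilicity, at pH 7.4; a higher number here means a more lipophilic compound, a lower number a more polar compound. Among the three measured compounds, compound 3 gives 4.3, the highest of the set; compound 2 comes nearest, beyond the scatter, and compound 1 sits furthest away, also beyond the scatter. The compound not yet measured is compound 4 `Fc1ccc(OCc2cc(OCC3(F)COC3)nc(-c3ccccn3)n2)c(F)c1F`. It differs from compound 3 in one place: (3-fluorooxetan-3-yl)methoxy in place of 3,3-dimethylazetidin-1-yl on an aromatic carbon. Among the measured compounds shown here, no step between measured compounds is given that would show what this swap does, so the expectation rests on the compounds themselves. Compound 4 is expected to fall, with a step of about a number 1.00 log units lower from compound 3 to compound 4 (beyond the scatter), beyond the scatter. Compound 4 is therefore estimated at 3.3, in the range 2.7 to 3.9.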

Compound 4, distribution coefficient: 4
Estimate against measurement, compound 4: 0.70 log units below; the whole stated range lies below it.
By their numbers in this assay, from the lowest: compound 1; then compound 2; then compounds 4 and 3 (each within the scatter of the next).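

In this assay, placing (3-fluorooxetan-3-yl)methoxy where 3,3-dimethylazetidin-1-yl stood on this aromatic carbon gives a number 0.30 log units lower from compound 3 to compound 4 (within the scatter). The two groups share a four-membered ring but differ in their atoms, with oxygen and fluorine in one and nitrogen in the other, yet this read-out does not separate them. No measurement shown explains this result. Open, on these data alone, is how a morpholine or a carboxylic acid at this position would compare with compound 3. Also open, as far as these compounds go, is whether this swap would give a similar result on another core.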